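The compounds below may be only part of what the source reports. "The series", "measured", "known", "first", "only" and "open" are said of these compounds alone.

Measured in a functional assay on HUVEC cells (Homo sapiens) for antiproliferative activity, read by MTT assay, with a stated time of 24 h; on this read-out higher numbers stand for weaker inhibition and lower numbers for stronger inhibition:
- Compound 1 `COc1cccc(C(=O)Oc2ccc3c(=O)c(-c4cc(OC)c(OC)cc4OC)coc3c2)c1`: > 10000 nM (a limit)
- Compound 2 `COc1cc(OC)c(-c2coc3cc(OCc4ccccc4C)ccc3c2=O)cc1OC`: 4830 nM
- Compound 3 `COc1cc(OC)c(-c2coc3cc(OCc4ccccc4C#N)ccc3c2=O)cc1OC`: > 10000 nM (a limit)

Compound 3 gives > 10000 nM, which is a limit and not a number. Among the measured compounds shown here, this is the ceiling of the series so far: the limit of > 10000 nM in this assay, at which 2 of the 3 values shown sit.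

The next compound, compound 4 `COc1cc(OC)c(-c2coc3cc(OCc4cccc(F)c4)ccc3c2=O)cc1OC`, differs from compound 3 in one place: 3-fluorophenyl in place of 2-cyanophenyl on a saturated chain carbon bound to an oxygen on an aromatic ring. Put simply, 3-fluorophenyl stands in place of 2-cyanophenyl on a saturated chain carbon bound to an oxygen on an aromatic ring.

The most useful measured comparison is an at least 2.0-fold higher number from compound 2 to compound 3 (0.31 log units; beyond the scatter), where cyano replaces methyl on an aromatic carbon. The comparison an at least 2.0-fold lower number from compound 1 to compound 2 (0.31 log units; beyond the scatter) shows that compound 2 also sits clear of compound 1, whereas a step that the two limits leave unreadable from compound 1 to compound 3 gives no usable size. For the measured compounds named here, no measured compound carries 3-fluorobenzyl, so that group is untested here. Compound 4 also lacks the cyano group, so compound 2 at 4830 nM is the best available guide, and a modest fall in the number is expected. Even so, a reading at the limit remains possible for compound 4.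

The expected change is an at least 1.6-fold lower number from compound 3 to compound 4 (0.22 log units; that floor lies within the scatter).

The estimate for compound 4 is 6000 nM, with an expected range of 2500 nM to 10000 nM.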

Compound 4, half-maximal inhibitory concentration: 5300 nM
Compound 4: middle estimate off by 1.1-fold (0.05 log units), on the high side; low and high end bracket the measured number.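

In this assay, a readable number returns at this saturated chain carbon bound to an oxygen on an aromatic ring once 3-fluorophenyl stands in place of 2-cyanophenyl, with an at least 1.8-fold lower number from compound 3 to compound 4 (0.27 log units; that floor lies within the scatter). Set against the 2-methylphenyl group, the same 3-fluorophenyl group gives a 1.1-fold higher number from compound 2 to compound 4 (0.04 log units; within the scatter), so these two different groups cannot be told apart here, while the 2-cyanophenyl group of compound 3 goes against them by reaching the limit. Putting 3-fluorobenzyl in place of (3-methoxyphenyl)carbonyl on the oxygen gives an at least 1.8-fold lower number from compound 1 to compound 4 (0.27 log units; that floor lies within the scatter), and this step and the one from compound 3 are floors rather than full sizes, as each starts from a limit: the limit of > 10000 nM in this assay, at which 2 of the 4 values shown sit.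

On these data alone, whether the nitrile itself or its place on the ring sets compound 3 apart stays open, and separating the two would take a pair such as 3-cyanobenzyl and 2-fluorobenzyl. As far as these compounds go, how an amine or a carboxylic acid on this ring, or a longer chain in place of the benzyl group, would read in this assay also remains open.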